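The source may report more compounds than this note shows. Statements on the series, on what has been measured and on what is new or still open speak of the compounds shown alone.

Series with a shared core and a trifluoromethyl-bearing amide side chain; only one group on the core is exchanged. In a functional assay on HEK293 cells for activation of melanin-concentrating hormone receptor 1 (Rattus norvegicus), read by inositol phosphate accumulation (a higher number here means that more compound is needed for the effect, a lower number that less compound is needed), compound 1 `CC(C)C(=O)NC1CCN(c2ccc3cc(NC(=O)CCc4ccc(C(F)(F)F)cc4)ccc3n2)C1` gives 90 nM. Compound 2 `O=C(CCc1ccc(C(F)(F)F)cc1)Nc1ccc2nc(N3CCC4(CCNC4)C3)ccc2c1` gives 140 nM, and compound 3 `O=C(CCc1ccc(C(F)(F)F)cc1)Nc1ccc2nc(N3CC4CCC3CC4)ccc2c1` gives 190 nM, the highest of the three numbers. The steps of a 1.6-fold higher number from compound 1 to compound 2 (0.19 log units; within the scatter) and a 1.4-fold higher number from compound 2 to compound 3 (0.13 log units; within the scatter) stay within the scatter; only a 2.1-fold higher number from compound 1 to compound 3 (0.32 log units; beyond the scatter) goes beyond it, modestly. Compound 4 `CCN(CC)c1ccc2cc(NC(=O)CCc3ccc(C(F)(F)F)cc3)ccc2n1` differs from compound 3 by a group of 5 heavy atoms (4 carbon, 1 nitrogen; no ring) in place of a group of 8 heavy atoms (7 carbon, 1 nitrogen; 2 six-membered non-aromatic rings with 1 hetero atom each), on an aromatic carbon. All three measured steps exchange groups at this same carbon and none moves the number far, so in this assay a small step toward a higher number is expected, possibly none beyond the scatter. For compound 4 the estimate is 300 nM, within 100 nM to 900 nM. That amounts to an expected 1.6-fold higher number from compound 3 to compound 4 (0.20 log units; within the scatter).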

Compound 4, half-maximal effective concentration: 830 nM
Compound 4: the middle estimate sits 2.8-fold (0.44 log units) below what was measured; the range from low to high includes it.
By their numbers in this assay, from the lowest: compounds 1, 2 and 3 (each within the scatter of the next, the first and the last beyond it); then compound 4.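

In this assay the position on the aromatic carbon next to the ring nitrogen proves sensitive to the exchange after all, since diethylamino gives the steps of a 4.4-fold higher number from compound 3 to compound 4 (0.64 log units; beyond the scatter) and a 5.9-fold higher number from compound 2 to compound 4 (0.77 log units; beyond the scatter) and also a 9.2-fold higher number from compound 1 to compound 4 (0.96 log units; beyond the scatter) and all three lie beyond the scatter. Among the listed compounds, the only group without a ring also gives the highest number, while the three ring-bearing groups stay much closer together.

Diethylamino differs from those groups in both ring and atom count, so unsubstituted pyrrolidin-1-yl or piperidin-1-yl would help separate the two. No measurement offered here accounts for the rise.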